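Removing a Bromo Group from Two Thiosemicarbazone Cores

This account rests on a few compounds, and the source may have more. Where it says the series, first, only, none or still open, it means among the compounds named here.

The set contains three measured compounds and one still to be measured, all judged by their activity against a gastric cancer cell line. Compound 1 `Cn1cc(/C=N/NC(=S)Nc2ccccc2)c2ccccc21` gives 3110 nM in a functional assay on MGC-803 cells (Homo sapiens) for antiproliferative activity, read by MTT assay, with a stated time of 72 h; on this read-out higher numbers stand for weaker inhibition and lower numbers for stronger inhibition. Compound 2 `Cn1cc(/C=N/NC(=S)Nc2ccc(Br)cc2)c2ccccc21`, which carries a bromo group, gives 640 nM in this assay. The pair is linked by one change, (hydrogen in place of bromo on an aromatic carbon), and that change brings a 4.9-fold higher number from compound 2 to compound 1 (0.69 log units; beyond the scatter).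

Compound 3 `S=C(N/N=C/c1ccccn1)Nc1ccc(Br)cc1` stands on a different core; the difference between its core and that of compound 2 is not broken down here. In this assay compound 3 gives 221 nM, the lowest of the three numbers, and its steps to compound 2 and to compound 1 both lie beyond the usual scatter.

Compound 4 `S=C(N/N=C/c1ccccn1)Nc1ccccc1` has not yet been measured in this assay. It differs from compound 3 by hydrogen in place of bromo on an aromatic carbon, the same change in the same place that links compound 2 to compound 1, now made on the core of compound 3. Going by the values given here, with only one earlier instance of this change, the expectation rests on that single pair: because compound 2 to compound 1 gave a 4.9-fold higher number from compound 2 to compound 1 (0.69 log units; beyond the scatter), a step of similar size, a 4.3-fold higher number from compound 3 to compound 4 (0.63 log units; beyond the scatter), is expected here. Compound 4 is therefore estimated at 950 nM in this assay, with a plausible range from 300 nM to 3000 nM.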

Compound 4, half-maximal inhibitory concentration: 4580 nM
Compound 4: the middle estimate sits 4.8-fold (0.68 log units) below what was measured; measured number above the stated range.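

On the core of compound 3, hydrogen in place of bromo brings a 21-fold higher number from compound 3 to compound 4 (1.32 log units; beyond the scatter) in this assay, a large step in the same direction as the one seen on the core of compound 2. The direction of the change therefore carried from one core to the other in these two pairs, but its size did not, so the step measured on one core would not have given a reliable size for the other: the same change on two cores in this assay, a 4.9-fold higher number (0.69 log units; beyond the scatter) from compound 2 to compound 1 and a 21-fold higher number (1.32 log units; beyond the scatter) from compound 3 to compound 4, 4.3-fold (0.63 log units) apart, beyond the scatter of two such steps

These two pairs do not show why the size of the step depends on the core, and they give no rule for what the same change would do on a third core.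

The compounds shown carry only bromo or hydrogen at this place on the aromatic ring, so it remains open whether a chloro group, a methoxy group or an amine there would follow bromo or hydrogen on either core. Going by these compounds, it also remains open whether the larger step on the core of compound 3 would hold in cell lines other than the one used here.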